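Removing the Trifluoromethyl Group from Compound 2

This account rests on a few compounds, and the source may have more. Where it says the series, first, only, none or still open, it means among the compounds named here.

In a functional assay on the whole organism with Mus musculus as the target (a lower number here means that less compound is needed, a higher number that more compound is needed for the effect), compound 2 `O=c1oc2cccnc2n1CCN1CCN(c2cccc(C(F)(F)F)c2)CC1` gives 11.4 mg/kg. In this assay compound 1 `O=c1oc2ccccc2n1CCN1CCN(c2cccc(C(F)(F)F)c2)CC1` gives 30.2 mg/kg.

Going by the values given here, compound 2 has the lowest of the two numbers measured; compound 1 is its only neighbour, and the gap between them lies beyond the usual scatter. Compound 3 `O=c1oc2cccnc2n1CCN1CCN(c2ccccc2)CC1` keeps the core of compound 2 and differs from it in one place: hydrogen in place of trifluoromethyl on an aromatic carbon, meta to a large group. Among the compounds with values here, no measured pair shows this kind of change, so its size in this assay is unknown from the data. A modest rise in the dose is expected, beyond the scatter but not large. Compound 3 is estimated at 22 mg/kg, within 7 mg/kg to 70 mg/kg, which means an expected step of a 1.9-fold higher number from compound 2 to compound 3 (0.29 log units; within the scatter).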

Compound 3, dose for half-maximal effect: 19.4 mg/kg
Compound 3: the middle estimate sits 1.1-fold (0.05 log units) above what was measured; the range from low to high includes it.
By their numbers in this assay, from the lowest: compounds 2, 3 and 1 (each within the scatter of the next, the first and the last beyond it).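

In this assay, hydrogen in place of trifluoromethyl on an aromatic carbon, meta to a large group, gives a 1.7-fold higher number from compound 2 to compound 3 (0.23 log units; within the scatter). Compound 1 and compound 2 both carry trifluoromethyl at this place and could say nothing about it, whereas compound 3 shows that, on this core, the value stays within the scatter of compound 2 without that group. No measurement among the data bears on why this is so.

The compounds shown hold only trifluoromethyl and hydrogen at this carbon, so it stays open how a chlorine atom, a methoxy group or a nitrile would read there. From the compounds shown here alone, it also stays open whether the same change on the core of compound 1 would give a step of similar size.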